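A few compounds are considered here, and "the series" means these few. Any claim that something is new, unique, unknown or untested is made for them only; others in the source may bear on it.

In a functional assay on G-361 cells (Homo sapiens) for cytotoxicity, read by MTT assay, with a stated time of 3 days (on this read-out higher numbers stand for weaker inhibition and lower numbers for stronger inhibition), compound 1 (`N#Cc1c(Cl)nc(SCc2nc3ccccc3[nH]2)nc1-c1ccccc1`) stands at 12.5 nM and compound 2 (`N#Cc1c(NNC(N)=S)nc(SCc2nc3ccccc3[nH]2)nc1-c1ccccc1`) at 3.96 nM, while compound 3 (`N#Cc1c(-c2ccccc2)nc(SCc2nc3ccccc3[nH]2)nc1N1CCNCC1`) gives 2.5 nM as the lowest number of the three. That number lies within the scatter of compound 2 and beyond the scatter of compound 1. Compound 4 (`Cc1ccc(S(=O)(=O)N2CCN(c3nc(SCc4nc5ccccc5[nH]4)nc(-c4ccccc4)c3C#N)CC2)cc1`) carries (4-methylphenyl)sulfonyl in place of hydrogen on an amine nitrogen in a ring. Going by the values given here, no measured step changes that nitrogen. The nearest evidence is replacement on an aromatic carbon: a 5.0-fold lower number from compound 1 to compound 3 (0.70 log units; beyond the scatter) and a 3.2-fold lower number from compound 1 to compound 2 (0.50 log units; beyond the scatter) are modest, and a 1.6-fold lower number from compound 2 to compound 3 (0.20 log units; within the scatter) stays within the scatter. No step beyond the scatter is therefore expected in this assay, with only a slight lean towards a higher number. The estimated change is a 1.6-fold higher number from compound 3 to compound 4 (0.20 log units; within the scatter) and stays within the scatter. For compound 4 the estimated value is 4 nM (expected range 1.2 nM to 15 nM).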

Compound 4, half-maximal inhibitory concentration: 4.38 nM
Compound 4: the middle estimate sits 1.1-fold (0.04 log units) below what was measured; the measured number falls inside the stated range.
By their numbers in this assay, from the lowest: compounds 3, 2 and 4 (each within the scatter of the next); then compound 1.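

With (4-methylphenyl)sulfonyl in place of hydrogen on the amine nitrogen in a ring, a 1.8-fold higher number from compound 3 to compound 4 (0.24 log units; within the scatter) in this assay. At this nitrogen, the hydrogen and a group of 10 heavy atoms therefore cannot be told apart on this read-out, so a free amine hydrogen is not needed for a low nanomolar number, at least with this one sulfonyl group. No available measurement offers an explanation for this result.

Open, going by these compounds, is whether a methylsulfonyl or an acetyl group on that nitrogen would read the same. Also open, on these data alone, is whether a carboxylic acid on the aromatic ring of the sulfonyl group would keep the number in this range.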